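The source may report more compounds than this note shows. Statements on the series, on what has been measured and on what is new or still open speak of the compounds shown alone.

Working notes on the series. Compound 1, `O=C(O)CCNC(=O)c1ccc(CN(c2ccc3c(c2)CCC3)c2nc(-c3ccc(C(F)(F)F)cc3)cs2)cc1`, is characterised in an in vitro assay on BHK cells for binding affinity to gastric inhibitory polypeptide receptor (Homo sapiens) (on this read-out lower numbers stand for stronger inhibition and higher numbers for weaker inhibition), where compound 1 gives 510 nM. Among the three measured compounds it holds the second highest number: compound 3, `O=C(O)CCNC(=O)c1ccc(CN(c2ccc(C(F)(F)F)cc2)c2nc(-c3ccc(Cl)cc3)cs2)cc1`, gives 1100 nM, a higher number beyond the scatter, while compound 2, `O=C(O)CCNC(=O)c1ccc(CC(c2ccc(Cl)cc2)c2nc(-c3ccc(C(F)(F)F)cc3)cs2)cc1`, gives 211 nM, a lower number beyond the scatter.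

Compound 4, `O=C(O)CCNC(=O)c1ccc(CN(c2ccc(OC(F)(F)F)cc2)c2nc(-c3ccc(C(F)(F)F)cc3)cs2)cc1`, is not yet measured. It differs from compound 1 by 4-(trifluoromethoxy)phenyl in place of 2,3-dihydro-1H-inden-5-yl on a nitrogen on an aromatic ring. Going by the values given here, no measured pair isolates this change. Compound 3, which also carries a fluorinated aryl group on the nitrogen, gives the highest number seen, so a modest rise in the number is expected for compound 4, with the step from compound 1 to compound 4 estimated as a 1.5-fold higher number from compound 1 to compound 4 (0.17 log units; within the scatter), near the edge of the scatter. Compound 4 is therefore expected to give about 750 nM, within a range of 300 nM to 1800 nM.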

Compound 4, half-maximal inhibitory concentration: 480 nM
Estimate against measurement, compound 4: 1.6-fold (0.19 log units) above; the range from low to high includes it.
By their numbers in this assay, from the lowest: compound 2; then compounds 4 and 1 (each within the scatter of the next); then compound 3.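

In this assay, going by these compounds alone, 4-(trifluoromethoxy)phenyl in place of 2,3-dihydro-1H-inden-5-yl on this nitrogen gives a 1.1-fold lower number from compound 1 to compound 4 (0.03 log units; within the scatter), the first step that isolates a change at this position. For this pair, the position accepts either group, and the added oxygen and fluorine atoms leave the reading within the scatter. No available evidence bears on why the two groups read alike.

The compounds shown leave open whether this tolerance extends beyond aryl groups, such as to a butyl chain or a piperidine on the same nitrogen.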